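A few compounds are considered here, and "the series" means these few. Any claim that something is new, unique, unknown or untested is made for them only; others in the source may bear on it.

Compound 1 `O=C(NC1CCC(CN2CCN(c3cc(=O)c4cc(C(F)(F)F)cc([N+](=O)[O-])c4s3)CC2)CC1)c1ccccc1` gives 44.3 ug/mL in an ADME assay on Vero cells (Chlorocebus sabaeus) for cytotoxicity, read by MTT assay, with a stated time of 48 h; on this read-out lower numbers stand for stronger inhibition and higher numbers for weaker inhibition. Compound 2 `CC(=O)OC1CCC(CN2CCN(c3cc(=O)c4cc(C(F)(F)F)cc([N+](=O)[O-])c4s3)CC2)CC1` gives only a limit, > 64 ug/mL. Compound 3 `CC(=O)NC1CCC(CN2CCN(c3cc(=O)c4cc(C(F)(F)F)cc([N+](=O)[O-])c4s3)CC2)CC1` likewise gives only a limit, > 64 ug/mL.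

For the measured compounds named here, compound 1 thus stands as the one compound with a number in this assay, the other two sitting at the limit of > 64 ug/mL in this assay, at which 2 of the 3 values shown sit. Compound 4 `COc1ccc(C(=O)OC2CCC(CN3CCN(c4cc(=O)c5cc(C(F)(F)F)cc([N+](=O)[O-])c5s4)CC3)CC2)cc1` differs from compound 1 by ((4-methoxyphenyl)carbonyl)oxy in place of benzamido on a saturated ring carbon. Going by the values given here, two measured steps bear on this change: an at least 1.4-fold higher number from compound 1 to compound 2 (0.15 log units; that floor lies within the scatter), which swaps the same benzamido for an ester, and an at least 1.4-fold higher number from compound 1 to compound 3 (0.15 log units; that floor lies within the scatter); both carry the number up to the limit. Compound 4 is therefore expected to show a higher number, a 1.4-fold higher number from compound 1 to compound 4 (0.13 log units; within the scatter), most likely again reaching the limit. Compound 4 is estimated at 60 ug/mL, within 35 ug/mL to 110 ug/mL.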

Compound 4, half-maximal inhibitory concentration: > 64 ug/mL
Compound 4 was reported as a limit; the forecaster's own chance of this, stated with the estimate: 60%; middle value at least 1.0-fold (0.02 log units) away from the limit.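

In this assay compound 4 gives > 64 ug/mL, which is a limit and not a number. The ((4-methoxyphenyl)carbonyl)oxy group keeps an aromatic ring at this place, unlike the acetoxy and acetamido groups, yet the change gives an at least 1.4-fold higher number from compound 1 to compound 4 (0.15 log units; that floor lies within the scatter), so an aromatic ring here did not by itself yield a number. Compound 1 remains the only compound with a number: the limit of > 64 ug/mL in this assay, at which 3 of the 4 values shown sit.

The steps to compound 4 from compound 2 and compound 3 join two limits and cannot be read. From the compounds shown here alone, whether an amine or a carboxylic acid on this saturated ring carbon would give a number in this assay remains open.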